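Methyl to Methoxy: From Compound 2 to Compound 3

The source may hold more compounds than are shown below. What is called first, only, known or untested is meant among the compounds shown, and "the series" means these compounds.

compound 1 `CCNc1cc(-c2ccc(NC(=O)Nc3cccc(Cl)c3)cc2C)ccn1`: 16600 nM
compound 2 `CCNc1cc(-c2ccc(NC(=O)Nc3ccccc3Cl)cc2C)ccn1`: > 30000 nM

In a functional assay on BT-483 cells (Homo sapiens) for cytotoxicity, read by MTT assay, with a stated time of 24 h (on this read-out higher numbers stand for weaker inhibition and lower numbers for stronger inhibition), compound 1 gives 16600 nM. For compound 2 the assay reports only a limit, > 30000 nM. Going by the values given here, the single measured step, an at least 1.8-fold higher number from compound 1 to compound 2 (0.25 log units; that floor lies within the scatter), concerns the position of the chlorine and ends at the limit of > 30000 nM in this assay, at which 1 of the 2 values shown sits.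

Compound 3 `CCNc1cc(-c2ccc(NC(=O)Nc3ccccc3Cl)cc2OC)ccn1` differs from compound 2 by methoxy in place of methyl on an aromatic carbon. Among the compounds with values here, no measured step exchanges a methyl for a methoxy, so the only guide is where compound 2 stands, at the limit. Compound 3 is therefore expected to give about 30000 nM, between 10000 nM and 100000 nM. This means an expected step of a number no higher from compound 2 to compound 3 (the limit leaves the size open), and a fair chance that again only a limit is reported.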

Compound 3, half-maximal inhibitory concentration: > 30000 nM
Compound 3: no number, only a limit; the forecaster's own chance of this, stated with the estimate: 60%; the middle value lies on the limit itself.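

Going by these compounds alone, no step from compound 2 to compound 3 can be read, because both compounds stop at a limit rather than a number: the limit of > 30000 nM in this assay, at which 2 of the 3 values shown sit. Going by these compounds, whether methoxy in place of methyl changes the result in this assay stays open.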